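Replacing the 2-(trifluoromethyl)phenyl group of compound 3

This account rests on a few compounds, and the source may have more. Where it says the series, first, only, none or still open, it means among the compounds named here.

Of the compounds shown here, three sharing one core have been measured in an ADME assay on a cell-free system (plasma, Homo sapiens) for protein binding; a higher number here means a larger unbound share of the compound, a lower number a smaller unbound share. Compound 1 (`Cn1cnc(S(=O)(=O)N2C[C@@H]3[C@H](C2)[C@@]3(CNC(=O)c2cc(Cl)cc(Cl)c2)CC2CC2)c1`) gives 0.02, compound 2 (`Cn1cnc(S(=O)(=O)N2C[C@@H]3[C@H](C2)[C@@]3(CNC(=O)c2ccccc2Cl)CC2CC2)c1`) gives 0.03, and compound 3 (`Cn1cnc(S(=O)(=O)N2C[C@@H]3[C@H](C2)[C@@]3(CNC(=O)c2ccccc2C(F)(F)F)CC2CC2)c1`) gives 0.07, the highest of the three numbers.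

The next compound, compound 4 (`Cn1cnc(S(=O)(=O)N2C[C@@H]3[C@H](C2)[C@@]3(CNC(=O)c2c(Cl)cccc2Cl)CC2CC2)c1`), carries 2,6-dichlorophenyl in place of 2-(trifluoromethyl)phenyl on a carbonyl carbon. Going by the values given here, no measured step makes this exact change, and no measured compound carries the 2,6-dichlorophenyl group. The closest evidence is a 2.3-fold higher number from compound 2 to compound 3 (0.37 log units; beyond the scatter), a modest step beyond the scatter, in which trifluoromethyl takes the place of chloro on an aromatic carbon. Compound 4 reverses that exchange in part, losing the trifluoromethyl and carrying chloro instead. The two chlorine-bearing groups measured so far both stand lower than compound 3: a 3.5-fold higher number from compound 1 to compound 3 (0.54 log units; beyond the scatter) is also modest, while a 1.5-fold higher number from compound 1 to compound 2 (0.18 log units; within the scatter) lies within the scatter, so the two chlorinated compounds do not separate from each other.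

A small downward move is therefore expected, and the estimate is a 1.8-fold lower number from compound 3 to compound 4 (0.24 log units; within the scatter), which would stay within the scatter. For compound 4 the estimated unbound fraction is 0.04, with an expected range of 0.02 to 0.08.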

Compound 4, unbound fraction: 0.08
Estimate against measurement, compound 4: 2.0-fold (0.30 log units) below, and the stated range covers the measured number.
By their numbers in this assay, from the lowest: compounds 1 and 2 (each within the scatter of the next); then compounds 3 and 4 (each within the scatter of the next).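

In this assay the exchange gives a 1.1-fold higher number from compound 3 to compound 4 (0.06 log units; within the scatter) and so leaves 2,6-dichlorophenyl and 2-(trifluoromethyl)phenyl on this carbonyl carbon unseparated, which shows that a group carrying chlorine and no trifluoromethyl can match compound 3 in this assay. Chloro in place of hydrogen on an aromatic carbon gives a 2.7-fold higher number from compound 2 to compound 4 (0.43 log units; beyond the scatter) as a modest step beyond the scatter, whereas the earlier chlorinated compounds, compound 1 and compound 2, did not separate from each other. The step of a 4.0-fold higher number from compound 1 to compound 4 (0.60 log units; beyond the scatter), also modest and beyond the scatter, shows that two dichlorophenyl groups on the same carbonyl carbon need not give the same unbound fraction, so the name of the substitution pattern counts here and not only the presence of chlorine; nothing available accounts for this.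

As far as these compounds go, it remains open whether 2,6-difluorophenyl or 2,6-dimethylphenyl on this carbonyl carbon would stand with compound 3 and compound 4 or with the lower pair. From the compounds shown here alone, it is equally open how a phenyl group bearing a methoxy group, a nitrile or an amine would fare in this assay at this position.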